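This account rests on a few compounds, and the source may have more. Where it says the series, first, only, none or still open, it means among the compounds named here.

Measured in a functional assay on SK-BR-3 cells (Homo sapiens) for antiproliferative activity, read by MTT assay, with a stated time of 72 h; on this read-out higher numbers stand for weaker inhibition and lower numbers for stronger inhibition:

compound 1 `CCN1CCN(c2cc(C)c3cc(NC(=O)c4ccc(C)cc4)ccc3n2)CC1` gives 11400 nM
compound 2 `CCN1CCN(c2cc(C)c3cc(NC(=O)c4ccccc4Br)ccc3n2)CC1` gives 39200 nM
compound 3 `CCN1CCN(c2cc(C)c3cc(NC(=O)c4ccc5ccccc5n4)ccc3n2)CC1` gives 3760 nM

Compound 3 has the lowest number of the three, and its steps to both others lie beyond the scatter. In compound 4 `CCN1CCN(c2cc(C)c3cc(NC(=O)c4cccc(F)c4)ccc3n2)CC1`, 3-fluorophenyl takes the place of quinolin-2-yl on a carbonyl carbon (3-fluorophenyl in place of quinolin-2-yl on a carbonyl carbon). Two measured steps bring in quinolin-2-yl. In place of 4-methylphenyl it gave a modest step, a 3.0-fold lower number from compound 1 to compound 3 (0.48 log units; beyond the scatter), and in place of 2-bromophenyl a large one, a 10-fold lower number from compound 2 to compound 3 (1.02 log units; beyond the scatter). Among the compounds with values here, no measured compound carries 3-fluorophenyl, so this is only a guide. Leaving quinolin-2-yl should therefore raise the number in this assay, probably modestly. The expected change is a 2.9-fold higher number from compound 3 to compound 4 (0.47 log units; beyond the scatter) here. For compound 4 the estimated value is 11000 nM, with an expected range from 4000 nM to 32000 nM.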

Compound 4, half-maximal inhibitory concentration: 24900 nM
Compound 4: middle estimate off by 2.3-fold (0.35 log units), on the low side; the measured number falls inside the stated range.
By their numbers in this assay, from the lowest: compound 3; then compound 1; then compounds 4 and 2 (each within the scatter of the next).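

At this carbonyl carbon, quinolin-2-yl with its two rings now stands ahead of three different single-ring groups, with a 6.6-fold higher number from compound 3 to compound 4 (0.82 log units; beyond the scatter). Among those groups, 3-fluorophenyl and 2-bromophenyl cannot be told apart, with a 1.6-fold lower number from compound 2 to compound 4 (0.20 log units; within the scatter), while 4-methylphenyl gives the lower number, with a 2.2-fold higher number from compound 1 to compound 4 (0.34 log units; beyond the scatter). No available evidence explains these differences.

The compounds shown leave open whether the second ring or the ring nitrogen of quinolin-2-yl matters more. Naphthalen-2-yl and pyridin-2-yl groups at this place would help to separate the two.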